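Ketone aryl swap in the aminothiophene series

This account rests on a few compounds, and the source may have more. Where it says the series, first, only, none or still open, it means among the compounds named here.

Of the compounds shown here, two have numbers so far. Compound 1 `Nc1scc(CN2CCN(c3ccc(Cl)c(C(F)(F)F)c3)CC2)c1C(=O)c1ccc(Cl)cc1` in a functional assay on CHO cells with adenosine receptor A1 (Homo sapiens) as the target, read by cAMP accumulation and immunoassay, with a stated time of 6 min, tested at 0.1 uM (a higher number here means a weaker effect of the compound at the concentration tested, a lower number a stronger effect), gives -12%. Compound 2 `Nc1scc(CN2CCN(c3c(F)cccc3F)CC2)c1C(=O)c1cccc(C(F)(F)F)c1` in this assay gives 1.3%, the higher of the two, standing beyond the scatter above compound 1. The next member, compound 3 `Nc1scc(CN2CCN(c3c(F)cccc3F)CC2)c1C(=O)c1ccc(Cl)cc1`, carries the same 4-chlorophenyl on the carbonyl carbon as compound 1 but otherwise matches compound 2; the change from compound 2 is 4-chlorophenyl in place of 3-(trifluoromethyl)phenyl on a carbonyl carbon. For the measured compounds named here, no measured pair differs only in this place, so the size of the step is unknown; compound 1 and compound 2 differ in two places at once and cannot settle it. A small step is expected, at most modestly downward, well within the spread of the two measured values. For compound 3 in this assay the estimate is -5%, between -25% and 15%, meaning an expected step of a number 6.3 percentage points lower from compound 2 to compound 3 (within the scatter).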

Compound 3, a percentage reported as activity, at one concentration (the size of the read-out at that concentration, not a potency): -23%
Estimate against measurement, compound 3: 18 percentage points above; measured number inside the range.
By their numbers in this assay, from the lowest: compound 3; then compound 1; then compound 2.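

On the carbonyl carbon, 4-chlorophenyl in place of 3-(trifluoromethyl)phenyl now has a measured size in this assay: a number 24.3 percentage points lower from compound 2 to compound 3 (beyond the scatter), showing that this aryl alone moves the read-out, and toward a stronger effect. With 4-chlorophenyl held on the carbonyl carbon, 2,6-difluorophenyl in place of 4-chloro-3-(trifluoromethyl)phenyl on an amine nitrogen in a ring gives a number 11 percentage points lower from compound 1 to compound 3 (beyond the scatter), so the second place of change also moves the read-out in its own right. Nothing at hand accounts for either step.

The ketone step changes both the substituent and its place on the phenyl, and the two remain unseparated: 3-chlorophenyl and 4-(trifluoromethyl)phenyl would be needed to tell them apart. On these data alone, how an unsubstituted phenyl, or a phenyl carrying an amine or a carboxylic acid, reads on the carbonyl carbon also remains open.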